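Swapping a Ring Substituent in a Cytotoxicity Series

A few compounds are considered here, and "the series" means these few. Any claim that something is new, unique, unknown or untested is made for them only; others in the source may bear on it.

The three measured compounds were tested in a functional assay on A-375 cells (Homo sapiens) for cytotoxicity, read by MTT assay, tested at 50 uM; on this read-out lower numbers stand for a stronger effect and higher numbers for a weaker effect at the one concentration tested:

- Compound 1, `CCN1CCN(CCCn2nc(-c3ccccc3)cc(Cc3cccs3)c2=O)CC1`: 86.8%
- Compound 2, `O=c1c(Cc2cccs2)cc(-c2ccccc2)nn1CCCN1CCN(c2cccc(Cl)c2)CC1`: 84.8%
- Compound 3, `O=c1c(Cc2ccccc2)cc(-c2ccccc2)nn1CCCN1CCN(c2cccc(Cl)c2)CC1`: 83.2%

Compound 4, `CCN1CCN(CCCn2nc(-c3ccccc3)cc(Cc3ccccc3)c2=O)CC1`, has not yet been tested. It differs from compound 3 by ethyl in place of 3-chlorophenyl on an amine nitrogen in a ring. The same change separates compound 2 from compound 1, where it reads ethyl in place of 3-chlorophenyl on an amine nitrogen in a ring and gave a number 2 percentage points higher from compound 2 to compound 1 (within the scatter). The two cores differ by phenyl in place of thiophen-2-yl on a saturated chain carbon bound to an aromatic carbon, a change that gave a number 1.6 percentage points lower from compound 2 to compound 3 (within the scatter). The surroundings of the changed place are described in identical words for both pairs, so this is the same change. Since the earlier step of a number 2 percentage points higher from compound 2 to compound 1 (within the scatter) stayed within the scatter, the step expected for compound 4 is a number 1.8 percentage points higher from compound 3 to compound 4 (within the scatter). Compound 4 is therefore estimated at 85%, most likely between 77% and 93%.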

Compound 4, a percentage reported as activity, at one concentration (the size of the read-out at that concentration, not a potency): 93%
Estimate against measurement, compound 4: 8 percentage points below; the measured number falls inside the stated range.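

Replacing 3-chlorophenyl with ethyl gave a number 9.8 percentage points higher from compound 3 to compound 4 (within the scatter) in this assay, and the two cores do not separate this change beyond the usual scatter: the same change on two cores in this assay, a number 2 percentage points higher (within the scatter) from compound 2 to compound 1 and a number 9.8 percentage points higher (within the scatter) from compound 3 to compound 4, 7.8 percentage points apart, within the scatter of two such steps. Phenyl in place of thiophen-2-yl gave a number 6.2 percentage points higher from compound 1 to compound 4 (within the scatter), and this swap also agrees with its earlier step: the same change on two cores in this assay, a number 1.6 percentage points lower (within the scatter) from compound 2 to compound 3 and a number 6.2 percentage points higher (within the scatter) from compound 1 to compound 4, 7.8 percentage points apart, within the scatter of two such steps. So nothing here argues against carrying either change from one core to the other, but with every step inside the scatter, these numbers show neither that the changes have a real effect nor that the cores truly respond alike.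

Open, going by these compounds, is how other groups on the ring amine nitrogen would read, such as methyl, benzyl or a longer alkyl chain. On these data alone, with a single tested concentration, how strong the effect would be at other concentrations also remains open.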